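Removing a Fluorine from a Cholesterol 24-Hydroxylase Inhibitor

The compounds below may be only part of what the source reports. "The series", "measured", "known", "first", "only" and "open" are said of these compounds alone.

Measured compounds:
compound 1, `Cc1cccc(-c2ccncc2)c1C(=O)N1CCC(O)(Cc2ccccc2)CC1`: 7.8 nM
compound 2, `O=C(c1cc(F)ccc1-c1ccncc1)N1CCC(O)(Cc2ccccc2)CC1`: 6.1 nM

In an assay for inhibition of cholesterol 24-hydroxylase (Homo sapiens), using NADPH, with stated times of 15 min and 5 min (on this read-out higher numbers stand for weaker inhibition and lower numbers for stronger inhibition), compound 1 gives 7.8 nM, and compound 2 gives 6.1 nM. Compound 2 has the lower of the two numbers, but its gap to compound 1 lies within the scatter, so the two cannot be told apart. Compound 3 `O=C(c1ccccc1-c1ccncc1)N1CCC(O)(Cc2ccccc2)CC1` has not been measured. It differs from compound 2 by hydrogen in place of fluoro on an aromatic carbon, meta to a large group and para to a pyridin-4-yl group. For the measured compounds named here, no pair of measured compounds isolates this change. Going by the values given here, the only hint is that compound 1 and compound 2, carrying a methyl or a fluoro on the shared core, give numbers within the scatter of each other, which gives no sign that a small group on this ring shifts the number much. The step expected here, a 1.5-fold higher number from compound 2 to compound 3 (0.17 log units; within the scatter), is small, at most a slight weakening near the scatter. Compound 3 is therefore estimated at 9 nM, within 4 nM to 20 nM.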

Compound 3, half-maximal inhibitory concentration: 7.9 nM
Compound 3: middle estimate off by 1.1-fold (0.06 log units), on the high side; the range from low to high includes it.
By their numbers in this assay, from the lowest: compounds 2, 1 and 3 (each within the scatter of the next).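

In this assay, hydrogen in place of fluoro on the aromatic carbon para to a pyridin-4-yl group gives a 1.3-fold higher number from compound 2 to compound 3 (0.11 log units; within the scatter), so this fluoro is not needed for a number in this range. Hydrogen in place of methyl gives a 1.0-fold higher number from compound 1 to compound 3 (0.01 log units; within the scatter), so the methyl is not needed either, something that could not be seen until a compound with hydrogen on the ring was at hand. No measurement here explains why these three compounds fall so close together.

Going by these compounds, it remains open whether a different group at the fluoro position, such as an amine, a methoxy group or a carboxylic acid, would leave the number where it is. The compounds shown also say nothing about changes elsewhere on the shared core, such as on the pyridin-4-yl group.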